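Fluoro on the aryl hydrazone arm and tolerated concentration

The source may report more compounds than this note shows. Statements on the series, on what has been measured and on what is new or still open speak of the compounds shown alone.

Measured compounds:
Compound 1 `Cc1ccc(C(=O)N/N=C/c2ccccc2)c(O)c1` — 578000 nM
Compound 2 `Cc1ccc(C(=O)N/N=C/c2cccc(F)c2)c(O)c1` — 166000 nM

The numbers come from an ADME assay on cells (Mus musculus, strain BALB/C) for cytotoxicity, read by MTT assay, with a stated time of 24 h; a higher number here means that more compound is tolerated, a lower number that less compound is tolerated. Compound 1 stands highest of the two measured compounds; its nearest neighbour is compound 2, and the step of a 3.5-fold lower number from compound 1 to compound 2 (0.54 log units; beyond the scatter) is the only one recorded. In words of structure, that step is fluoro in place of hydrogen on an aromatic carbon of the shared core of compound 1.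

Compound 3 `Cc1ccc(C(=O)N/N=C/c2ccc(F)cc2)c(O)c1` has not yet been measured in this assay. It differs from compound 1 by fluoro in place of hydrogen on an aromatic carbon. Among the measured compounds shown here, the one measured step that bears on this change is the step from compound 1 to compound 2, which also puts fluoro in place of hydrogen on the same six-membered aromatic ring, though at a different place; that step was modest and beyond the scatter, with a lower number. The same kind of change is therefore expected to move compound 3 in the same direction, with a step of about a 2.3-fold lower number from compound 1 to compound 3 (0.36 log units; beyond the scatter), though the different place leaves room for a smaller shift. Compound 3 is accordingly estimated at 250000 nM, within a range of 100000 nM to 600000 nM.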

Compound 3, half-maximal cytotoxic concentration: 568000 nM
Compound 3: middle estimate off by 2.3-fold (0.36 log units), on the low side; the measured number falls inside the stated range.
By their numbers in this assay, from the lowest: compound 2; then compounds 3 and 1 (each within the scatter of the next).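

In this assay, fluoro in place of hydrogen para to a large group gives a 1.0-fold lower number from compound 1 to compound 3 (0.01 log units; within the scatter), so at this place the change leaves no reading that can be told apart from compound 1. The earlier step, a 3.5-fold lower number from compound 1 to compound 2 (0.54 log units; beyond the scatter), put the same fluoro at a different place on the same six-membered aromatic ring and lay beyond the scatter, so the two steps together show that the outcome of this change is not the same at every place on that ring; a fluoro on the ring does not by itself bring a lower number. Nothing among the available data offers an explanation for why the two places part in this way.

The compounds shown leave open whether the tolerance seen at this place belongs to fluoro alone or would hold for a larger group there, such as chloro, methoxy or an amine. They also leave open what fluoro would do at the remaining places on the ring, and whether a second fluoro on the ring would change the number of compound 3.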